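The compounds below may be only part of what the source reports. "The series", "measured", "known", "first", "only" and "open" are said of these compounds alone.

Measured so far:
Compound 1, `CNC(=O)c1cc(Oc2ccc(NC(=O)c3cc(-c4ccc(OC)cc4)ncn3)cc2F)ccn1`. In a functional assay on MCF7 cells (Homo sapiens) for cytotoxicity, read by MTT assay, with a stated time of 72 h (a lower number here means a stronger inhibitor, a higher number a weaker inhibitor), compound 1 gives 46200 nM.
Compound 2, `CNC(=O)c1cc(Oc2ccc(NC(=O)c3cc(-c4ccc(C(F)(F)F)cc4)ncn3)cc2F)ccn1`. In this assay compound 2 reaches only the limit > 100000 nM; this is a limit of the assay, not a number.
Compound 3, `CNC(=O)c1cc(Oc2ccc(NC(=O)c3cc(-c4ccc(C)cc4)ncn3)cc2F)ccn1`. In this assay compound 3 gives 19200 nM.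

Of the two numbers, compound 3 holds the lowest; its nearest neighbour is compound 1, with a 2.4-fold lower number from compound 1 to compound 3 (0.38 log units; beyond the scatter). The three measured compounds differ only in the group on an aromatic carbon, and the steps there were an at least 2.1-fold higher number from compound 1 to compound 2 (0.33 log units; beyond the scatter) and an at least 5.2-fold lower number from compound 2 to compound 3 (0.71 log units; beyond the scatter).

Compound 4 is `CCc1ccc(-c2cc(C(=O)Nc3ccc(Oc4ccnc(C(=O)NC)c4)c(F)c3)ncn2)cc1`. It differs from compound 3 by methyl in place of hydrogen on a saturated chain carbon bound to an aromatic carbon; read one bond further out, methyl becomes ethyl, so 4-methylphenyl becomes 4-ethylphenyl. No measured step among these compounds tests this growth of a chain; the measured steps swap one group for another, and all were modest or at the limit. A change of the expected size a 1.1-fold lower number from compound 3 to compound 4 (0.05 log units; within the scatter) would sit within the scatter in this assay, with no clear direction. Compound 4 is therefore estimated at 17000 nM, with a range from 6000 nM to 50000 nM.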

Compound 4, half-maximal inhibitory concentration: 7630 nM
The estimate for compound 4 lay 2.2-fold (0.35 log units) above the measured number; low and high end bracket the measured number.
By their numbers in this assay, from the lowest: compound 4; then compound 3; then compound 1. At a limit, above all of these: compound 2.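

In this assay, within the data shown here, going from 4-methylphenyl to 4-ethylphenyl gives a 2.5-fold lower number from compound 3 to compound 4 (0.40 log units; beyond the scatter), so a single added methyl on a saturated chain carbon bound to an aromatic carbon moves the number beyond the scatter, and this is the first step here that grows a chain rather than swapping one group for another. Ethyl also compares well with methoxy, with a 6.1-fold lower number from compound 1 to compound 4 (0.78 log units; beyond the scatter), and compound 4 now holds the lowest number of the series. Against trifluoromethyl the change reads an at least 13-fold lower number from compound 2 to compound 4 (1.11 log units; beyond the scatter), but this step starts from a limit of compound 2, not a number: the limit of > 100000 nM in this assay, at which 1 of the 4 values shown sits.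

As far as these compounds go, whether a longer chain such as propyl, or a branched one such as isopropyl, would lower the number further stays open. So does whether an amine at the end of that chain would keep the same level.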